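A small swap on compound 2

A few compounds are considered here, and "the series" means these few. Any claim that something is new, unique, unknown or untested is made for them only; others in the source may bear on it.

Among the measured compounds shown here, in a functional assay on DU-145 cells (Homo sapiens) for cytotoxicity (a lower number here means a stronger inhibitor of growth, a higher number a weaker inhibitor of growth), compound 2 `COc1ccc(C2=C(c3ccc(SC)cc3)CC3CCCN3C2=O)cc1` gives 900 nM, the lower of the two numbers so far. Compound 1 `COc1ccc(C2=C(c3ccc(SC)cc3)CC3CCCN3C2=O)cc1OC(=O)CNC(=O)OC(C)(C)C` gives 10000 nM. Compound 3 `CSc1ccc(C2=C(c3ccc(SC)cc3)C(=O)N3CCCC3C2)cc1` differs from compound 2 by one exchange: methylsulfanyl in place of methoxy on an aromatic carbon. For the measured compounds named here, the only measured step, an 11-fold lower number from compound 1 to compound 2 (1.05 log units; beyond the scatter), took away a much larger group at another place, so it bears only weakly on this swap of two small groups. No firm direction can be drawn from it, and no change beyond the scatter is expected. The expected step is a 1.1-fold higher number from compound 2 to compound 3 (0.05 log units; within the scatter). Compound 3 is estimated at 1000 nM, within a range of 300 nM to 3500 nM.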

Compound 3, concentration for 50% growth inhibition: 8000 nM
Compound 3: the middle estimate sits 8.0-fold (0.90 log units) below what was measured; the measured number lies above the stated range.
By their numbers in this assay, from the lowest: compound 2; then compounds 3 and 1 (each within the scatter of the next).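

This position tolerates less than the small size of the exchange suggests. Methoxy and methylsulfanyl have the same heavy-atom and hydrogen-bond counts, and only one atom differs, yet in this assay the exchange gives an 8.9-fold higher number from compound 2 to compound 3 (0.95 log units; beyond the scatter). So a change on this aromatic carbon, para to a large group, need not be large to matter. Nothing available here accounts for the size of this step. On these data alone, whether a hydroxyl group, an amine or a longer chain such as ethoxy at this position would hold or lose growth inhibition remains open.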